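A few compounds are considered here, and "the series" means these few. Any claim that something is new, unique, unknown or untested is made for them only; others in the source may bear on it.

Measured so far:
compound 1, `O=C(NC(=S)Nc1ccc(Cl)c(-c2nc3ccccc3[nH]2)c1)c1ccc(OCc2ccc(Cl)c(Cl)c2)cc1` — in a functional assay on MGC-803 cells (Homo sapiens) for inhibition, read by MTT assay, with a stated time of 48 h (a lower number here means a stronger inhibitor, a higher number a weaker inhibitor), compound 1 gives 5170 nM
compound 2, `Cc1ccc(NC(=O)NC(=O)c2ccc(OCc3cccc(C(F)(F)F)c3)cc2)cc1-c1nc2ccccc2[nH]1` — in this assay compound 2 gives 13100 nM

Compound 2 stands at the higher of the two numbers in this assay; compound 1 lies beyond the scatter away from it, toward the stronger side. The two differ in more than one place, so what separates them cannot be assigned to any single part of the structures; only the two values themselves are known.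

Compound 3, `Cc1ccc(NC(=O)NC(=O)c2ccc(OCc3ccc(Cl)c(Cl)c3)cc2)cc1-c1nc2ccccc2[nH]1`, is not yet measured. It keeps the core of compound 2 and changes the benzyl ether tail: 3,4-dichlorophenyl in place of 3-(trifluoromethyl)phenyl on a saturated chain carbon bound to an oxygen on an aromatic ring. For the measured compounds named here, the tail that enters is the one found in compound 1, whose value in this assay is the lower of the two, but compound 1 also carries other changes, so that number gives only a loose pointer, not a step. Going by the values given here, with no step between compounds differing in this place alone, the expectation is a small move toward a lower number, of a size that may well stay within the scatter; the step from compound 2 to compound 3 in this assay is estimated at a 1.5-fold lower number from compound 2 to compound 3 (0.19 log units; within the scatter). The estimate for compound 3 in this assay is therefore 8500 nM, with a range from 3000 nM to 25000 nM.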

Compound 3, half-maximal inhibitory concentration: 6080 nM
Compound 3: middle estimate off by 1.4-fold (0.15 log units), on the high side; the range from low to high includes it.
By their numbers in this assay, from the lowest: compounds 1 and 3 (each within the scatter of the next); then compound 2.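

In this assay, for the compounds shown here, the benzyl ether tail now has its first step in which only one place changes: 3,4-dichlorophenyl in place of 3-(trifluoromethyl)phenyl, on a saturated chain carbon bound to an oxygen on an aromatic ring, gives a 2.2-fold lower number from compound 2 to compound 3 (0.33 log units; beyond the scatter). The step is modest but beyond the scatter, so with the core of compound 2 held constant, this tail change alone shifts the number toward the stronger side. Going by these compounds alone, nothing measured so far accounts for the direction or size of this step.

Within the data shown here, the series holds only this one exchange at this place, so it remains open whether the same exchange would give a similar step on the core of compound 1, or whether either substituted tail differs from a plain unsubstituted benzyl. Also open, from the compounds shown here alone, is how this position would respond to a different kind of group, such as a pyridine ring in place of the substituted phenyl ring, a morpholine at the end of a longer chain, or a carboxylic acid on the tail.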